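Notes on the step from compound 3 to compound 4

This account rests on a few compounds, and the source may have more. Where it says the series, first, only, none or still open, it means among the compounds named here.

Three compounds of the series have been run in an ADME assay on A549 cells (Homo sapiens) for cytotoxicity, read by CellTiter-Glo; on this read-out higher numbers stand for lower toxicity in this test and lower numbers for higher toxicity in this test. Compound 1 `Cc1c(Cc2ccccc2)c(=O)oc2cc(OCC(O)CNc3nc4ccccc4[nH]3)ccc12` in this assay gives only a limit, > 100000 nM. Compound 2 `Cc1ccc2nc(NCC(O)COc3ccc4c(C)c(Cc5ccccc5)c(=O)oc4c3)sc2c1` in this assay likewise gives only a limit, > 100000 nM. The step that the two limits leave unreadable from compound 1 to compound 2 is accordingly not readable. Among the compounds with values here, compound 3 `Cc1c(Cc2ccc(C(C)(C)C)cc2)c(=O)oc2cc(OCC(O)CN3CCC(C(N)=O)CC3)ccc12` is the one member with a number: in this assay compound 3 gives 14700 nM, so it stands apart as the only measured value, with the limit of > 100000 nM in this assay, at which 2 of the 3 values shown sit, marking where the other two sit.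

Compound 4 `Cc1c(Cc2ccc(-c3ccc(C(F)(F)F)cc3)cc2)c(=O)oc2cc(OCC(O)CN3CCC(C(N)=O)CC3)ccc12` differs from compound 3 in one place: 4-(trifluoromethyl)phenyl in place of tert-butyl on an aromatic carbon. Within the data shown here, no measured step touches this exchange; the single step recorded, from compound 1 to compound 2, concerns a different part of the molecule and its size is not readable. Among the measured compounds shown here, the data therefore support no expectation of a step in this assay beyond the scatter, in either direction. The estimate for compound 4 is accordingly 12000 nM, within 3000 nM to 50000 nM. The expected step is a 1.2-fold lower number from compound 3 to compound 4 (0.09 log units; within the scatter), with a wide range because nothing measured anchors it.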

Compound 4, half-maximal cytotoxic concentration: > 100000 nM
Compound 4 was reported as a limit (the forecaster's own chance of this, stated with the estimate: 15%); middle value at least 8.3-fold (0.92 log units) away from the limit.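

At this position, an aromatic carbon of a six-membered aromatic ring of carbon only, para to a large group, the series gives its first readable step in this assay: 4-(trifluoromethyl)phenyl in place of tert-butyl gives an at least 6.8-fold higher number from compound 3 to compound 4 (0.83 log units; beyond the scatter). Compound 4 gives only a limit, > 100000 nM, not a number. The exchange therefore runs towards lower toxicity in this test, and compound 3 remains the only member with a number: the limit of > 100000 nM in this assay, at which 3 of the 4 values shown sit.

Going by these compounds, the true size of the step stays open, and so does the question of whether it follows the added ring or the trifluoromethyl on that ring. A plain phenyl or a 4-methoxyphenyl at this position would separate the two.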